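Swapping the aryl group on the sulfonamide of compound 3

This account rests on a few compounds, and the source may have more. Where it says the series, first, only, none or still open, it means among the compounds named here.

Measured so far:
Compound 1, `O=C(NCCCNc1nccc(-c2c(-c3cccc(F)c3)nc3sccn23)n1)c1ccc(Cl)cc1`, in a functional assay on SK-MEL-28 cells (Homo sapiens) for cytotoxicity, read by MTT assay (on this read-out lower numbers stand for stronger inhibition and higher numbers for weaker inhibition), compound 1 gives > 20000 nM, which is a limit of the assay and not a number.
Compound 2, `O=S(=O)(NCCNc1nccc(-c2c(-c3cccc(F)c3)nc3sccn23)n1)c1ccc(C(F)(F)F)cc1`, gives 8450 nM in this assay.
Compound 3, `O=S(=O)(NCCNc1nccc(-c2c(-c3cccc(F)c3)nc3sccn23)n1)c1ccc(Br)cc1`, gives 13500 nM in this assay.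

Compound 3 carries the highest of the two numbers, but its nearest neighbour is compound 2, and the step of a 1.6-fold higher number from compound 2 to compound 3 (0.20 log units; within the scatter) lies within the scatter, so the two cannot be told apart. Compound 1 reports only a limit, and the step of an at least 1.4-fold lower number from compound 1 to compound 3 (0.17 log units; that floor lies within the scatter) has a floor that is itself within the scatter.

Compound 4, `O=S(=O)(NCCNc1nccc(-c2c(-c3cccc(F)c3)nc3sccn23)n1)c1cccc(F)c1`, differs from compound 3 in one place: 3-fluorophenyl in place of 4-bromophenyl on a sulfonyl sulfur.

Among the compounds with values here, two measured steps bear on this. The step of a 1.6-fold higher number from compound 2 to compound 3 (0.20 log units; within the scatter) shows that changing the substituent on this aryl ring moved the number only within the scatter. The step of an at least 1.4-fold lower number from compound 1 to compound 3 (0.17 log units; that floor lies within the scatter) concerns a different part of the linker and adds little. A change of one halogen for another on the same ring is therefore expected to give no step beyond the scatter in this assay.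

Compound 4 is estimated at 12000 nM, within 4000 nM to 40000 nM, and the expected step is a 1.1-fold lower number from compound 3 to compound 4 (0.05 log units; within the scatter).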

Compound 4, half-maximal inhibitory concentration: 18300 nM
For compound 4 the middle estimate is 1.5-fold (0.18 log units) below the measured one, within the range that was stated.
By their numbers in this assay, from the lowest: compounds 2, 3 and 4 (each within the scatter of the next, the first and the last beyond it). At a limit, above all of these: compound 1.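

Replacing 4-bromophenyl with 3-fluorophenyl on the sulfonyl sulfur gives a 1.4-fold higher number from compound 3 to compound 4 (0.13 log units; within the scatter), so this swap alone cannot be told apart from repeat-measurement noise in this assay. Set against the 4-(trifluoromethyl)phenyl group, however, the same 3-fluorophenyl group gives a 2.2-fold higher number from compound 2 to compound 4 (0.34 log units; beyond the scatter), the first step among these sulfonamides to clear the scatter, though only modestly, and the 4-bromophenyl compound stays within the scatter of both. The step of an at least 1.0-fold lower number from compound 1 to compound 4 (0.03 log units; that floor lies within the scatter) fixes no size for the change from the amide to the sulfonamide linker, since compound 1 gives only a limit of the assay: the limit of > 20000 nM in this assay, at which 1 of the 4 values shown sits.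

The swap from compound 3 to compound 4 changes both the halogen and its place on the ring, so the compounds shown cannot separate these two changes, and a 4-fluorophenyl or a 3-bromophenyl group would be needed to do so. On these data alone, it also remains open how this assay would respond to an amine or a carboxylic acid on this aryl ring, or to a longer chain in the sulfonamide linker.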